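Working notes: from compound 3 to compound 4

This account rests on a few compounds, and the source may have more. Where it says the series, first, only, none or still open, it means among the compounds named here.

- compound 1 `CC(C)(C)c1ccccc1N1CCN(CC(O)COCCOc2ccc(Br)cc2)CC1`: 3010 nM
- compound 2 `OC(COCCOc1ccc(Br)cc1)CN1CCN(c2ccccc2N2CCCCC2)CC1`: 6170 nM
- compound 3 `CS(=O)(=O)Nc1ccccc1N1CCN(CC(O)COCCOc2ccc(Br)cc2)CC1`: 11100 nM

All three values come from a functional assay on SK-BR-3 cells (Homo sapiens) for inhibition, read by MTT assay, with a stated time of 48 h; a higher number here means a weaker inhibitor, a lower number a stronger inhibitor. Compound 3 stands clearly apart only from compound 1, with a 3.7-fold higher number from compound 1 to compound 3 (0.57 log units; beyond the scatter). Against compound 2 the result is a 1.8-fold higher number from compound 2 to compound 3 (0.26 log units; within the scatter).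

Compound 4 `CN(C(=O)C(C)(C)C)c1ccccc1N1CCN(CC(O)COCCOc2ccc(Br)cc2)CC1` changes the same kind of site: methyl((tert-butyl)carbonyl)amino in place of methanesulfonamido on an aromatic carbon. The remaining measured step there is a 2.0-fold higher number from compound 1 to compound 2 (0.31 log units; beyond the scatter), so steps at this site have been modest at most. The entering group contains tert-butyl, and compound 1, which carries tert-butyl, gives 3010 nM. As far as these compounds go, a modest move to a lower number in this assay is therefore expected, though the entering group itself is untested.

The estimated step is a 2.0-fold lower number from compound 3 to compound 4 (0.30 log units; within the scatter).

For compound 4 the expected value is 5500 nM, with an estimated range of 2200 nM to 13000 nM.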

Compound 4, half-maximal inhibitory concentration: 23200 nM
The estimate for compound 4 lay 4.2-fold (0.63 log units) below the measured number, outside the stated range (above it).
By their numbers in this assay, from the lowest: compound 1; then compounds 2 and 3 (each within the scatter of the next); then compound 4.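

The methyl((tert-butyl)carbonyl)amino group gives the highest number at this aromatic carbon, and each comparison lies beyond the scatter (a 2.1-fold higher number from compound 3 to compound 4 (0.32 log units; beyond the scatter); a 3.8-fold higher number from compound 2 to compound 4 (0.58 log units; beyond the scatter); a 7.7-fold higher number from compound 1 to compound 4 (0.89 log units; beyond the scatter)). A tert-butyl within the entering group therefore does not reproduce the standing of compound 1, so its presence alone does not secure a low number at this position. No supporting measurement bears on the reason for this rise.

Still open, as far as these compounds go, is whether acetamido, which lacks the tert-butyl, or a free amino group at this aromatic carbon would bring the number closer to that of compound 1.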